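Cyano for trifluoromethyl: working notes on compound 4

The compounds below may be only part of what the source reports. "The series", "measured", "known", "first", "only" and "open" are said of these compounds alone.

Measured so far in a functional assay on the whole organism for positive allosteric modulation, with Mus musculus as the target; a lower number here means that less compound is needed, a higher number that more compound is needed for the effect:
- compound 1 `CCC(=O)N(c1ccc(OC)cc1)C1CCCC1N(C)C` gives > 50 mg/kg; > 50 mg/kg (2 entries) (a limit, not a number)
- compound 2 `CN(C)C1CCCC1N(C=O)c1ccc(Cl)c(Cl)c1` gives > 50 mg/kg (a limit, not a number)
- compound 3 `CCC(=O)N(c1ccc(C(F)(F)F)cc1)C1CCCC1N(C)C` gives 10 mg/kg

Within the data shown here, compound 3 holds the only actual number, 10 mg/kg, so it is the sole reference point in this assay. The entries for compound 1 and compound 2 are limits of the assay.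

Compound 4 `CCC(=O)N(c1ccc(C#N)cc1)C1CCCC1N(C)C` carries cyano in place of trifluoromethyl on an aromatic carbon. Among the measured compounds shown here, no measured pair shows this change, so the size of the step in this assay can only be expected. The expectation leans toward a higher dose because compound 1 stays at > 50 mg/kg; > 50 mg/kg (2 entries), which is a limit. The expected move is a moderate one, a 2.5-fold higher number from compound 3 to compound 4 (0.40 log units; beyond the scatter), and a result at the assay limit remains possible. For compound 4 the estimated value is 25 mg/kg, with an expected range from 8 mg/kg to 70 mg/kg.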

Compound 4, dose for half-maximal effect: > 50 mg/kg
Compound 4: a limit, no number; the forecaster's own chance of this, stated with the estimate: 35%; at least 2.0-fold (0.30 log units) between middle value and limit.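

Cyano in place of trifluoromethyl on this aromatic carbon gives an at least 5.0-fold higher number from compound 3 to compound 4 (0.69 log units; beyond the scatter) in this assay, the first step in the series that can be read. Its size is only a lower bound, because the reading for compound 4 stops at a limit of the assay and not at a number: the limit of > 50 mg/kg in this assay, at which 2 of the 4 values shown sit. Among these compounds, with compound 1 and compound 4 both ending at limits, trifluoromethyl is so far the only group at this place, para to a large group, that yields a number, though compound 3 remains a single reference point.

On these data alone, how far past the limit compound 4 lies stays unknown, so cyano cannot be ranked against the methoxy of compound 1. As far as these compounds go, whether a number returns with trifluoromethoxy or a bromine atom at this place remains open, as does the effect of a longer chain on the amide carbonyl of compound 3.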